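A few compounds are considered here, and "the series" means these few. Any claim that something is new, unique, unknown or untested is made for them only; others in the source may bear on it.

Measured compounds:
- compound 1, `CC(=O)N1c2ccccc2CCC1C(=O)Nc1ccccc1O`: 49700 nM
- compound 2, `O=C(Nc1ccccc1O)C1CCc2ccccc2N1C(=O)c1ccccc1Cl`: 36800 nM

Both numbers come from a functional assay on NUGC-3 cells (Homo sapiens) for cytotoxicity, read by sulforhodamine B assay, with a stated time of 72 h; a lower number here means a stronger inhibitor of growth, a higher number a weaker inhibitor of growth. Compound 2 gives the lowest of the two numbers in this assay, the nearest being compound 1, and the step between them, a 1.4-fold lower number from compound 1 to compound 2 (0.13 log units; within the scatter), does not separate the two.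

Compound 3, `O=C(Nc1ccccc1O)C1CCc2ccccc2N1C(=O)c1ccc(Cl)cc1`, is not yet measured. It differs from compound 2 in one place: 4-chlorophenyl in place of 2-chlorophenyl on a carbonyl carbon.

Going by the values given here, the only measured step, a 1.4-fold lower number from compound 1 to compound 2 (0.13 log units; within the scatter), concerns a different exchange on the same carbonyl carbon and lies within the scatter. Among the compounds with values here, no measured pair shows how moving the chlorine on this phenyl from the 2- to the 4-position affects this assay. On this basis no step beyond the scatter is expected; compound 3 is estimated at 35000 nM, with a range of 12000 nM to 100000 nM, meaning an expected step of a 1.1-fold lower number from compound 2 to compound 3 (0.02 log units; within the scatter).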

Compound 3, concentration for 50% growth inhibition: 13400 nM
Beside the measured number, compound 3's estimate is 2.6-fold (0.42 log units) above it; low and high end bracket the measured number.
By their numbers in this assay, from the lowest: compound 3; then compounds 2 and 1 (each within the scatter of the next).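

In this assay, going by these compounds alone, the carbonyl carbon on the amide-type nitrogen in a ring now shows a step beyond the scatter: 4-chlorophenyl in place of 2-chlorophenyl gives a 2.7-fold lower number from compound 2 to compound 3 (0.44 log units; beyond the scatter) and so the place of the chlorine on this phenyl matters here, which the earlier compounds could not show. Against methyl, 4-chlorophenyl also separates, with a 3.7-fold lower number from compound 1 to compound 3 (0.57 log units; beyond the scatter) as its step, while 2-chlorophenyl does not, so compound 2 goes against any reading that a chlorophenyl alone is enough at this carbonyl carbon. No measurement shown explains the difference between the two chlorophenyl groups.

As far as these compounds go, how a plain phenyl, a 4-fluorophenyl or a 4-methoxyphenyl would stand on this carbonyl carbon remains open. Also open, from the compounds shown here alone, is whether the difference between the two chlorophenyl groups holds when the rest of the core changes.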